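Swapping a 2-fluorophenyl for a 3,4,5-trimethoxyphenyl

This account rests on a few compounds, and the source may have more. Where it says the series, first, only, none or still open, it means among the compounds named here.

Compound 1 `COc1cc(/C=C2\CN(S(=O)(=O)c3ccc(NC(C)=O)cc3)C/C(=C\c3cc(OC)c(OC)c(OC)c3)C2=O)cc(OC)c1OC` gives 3470 nM
Compound 2 `COc1cc(/C=C2\CN(S(=O)(=O)c3ccc(F)cc3)C/C(=C\c3cccc([N+](=O)[O-])c3)C2=O)cc(OC)c1OC` gives 4900 nM
Compound 3 `CC(=O)Nc1ccc(S(=O)(=O)N2C/C(=C\c3cccc([N+](=O)[O-])c3)C(=O)/C(=C/c3ccccc3F)C2)cc1` gives 10200 nM

These three numbers all come from a functional assay on SMMC-7721 cells (Homo sapiens) for cytotoxicity, read by MTT assay, with a stated time of 24 h (a lower number here means a stronger inhibitor, a higher number a weaker inhibitor), and each belongs to one compound. Compound 3 at 10200 nM stands highest of the three. That makes it the weakest inhibitor here, and its gaps to both other compounds lie beyond the usual scatter.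

The step to compound 4 `COc1cc(/C=C2\CN(S(=O)(=O)c3ccc(NC(C)=O)cc3)C/C(=C\c3cccc([N+](=O)[O-])c3)C2=O)cc(OC)c1OC` puts 3,4,5-trimethoxyphenyl in place of 2-fluorophenyl on a double-bonded chain carbon bound to a double-bonded ring carbon. Within the data shown here, no two measured compounds differ in one place only, so no direct step shows what this swap does. The entering group does occur in compound 1 at 3470 nM and in compound 2 at 4900 nM and both numbers lie under that of compound 3, although each of these compounds also differs from compound 4 in another place. A modest move towards a stronger inhibitor in this assay is therefore expected. The estimated step is a 2.3-fold lower number from compound 3 to compound 4 (0.36 log units; beyond the scatter) and it may end up close to the scatter. Compound 4 is expected at an estimated 4500 nM (range 2200 nM to 9000 nM).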

Compound 4, half-maximal inhibitory concentration: 1950 nM
Estimate against measurement, compound 4: 2.3-fold (0.36 log units) above, outside the stated range (below it).
By their numbers in this assay, from the lowest: compounds 4, 1 and 2 (each within the scatter of the next, the first and the last beyond it); then compound 3.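

In this assay, the swap of 2-fluorophenyl for 3,4,5-trimethoxyphenyl on a double-bonded chain carbon bound to a double-bonded ring carbon can now be read directly as a 5.2-fold lower number from compound 3 to compound 4 (0.72 log units; beyond the scatter) and points towards a stronger inhibitor with nothing else changed. The other place also gains its first direct reading, since acetamido in place of fluoro on an aromatic carbon gives a 2.5-fold lower number from compound 2 to compound 4 (0.40 log units; beyond the scatter) and so moves the number the same way. The third step, 3-nitrophenyl in place of 3,4,5-trimethoxyphenyl at a place described in the same words, gives a 1.8-fold lower number from compound 1 to compound 4 (0.25 log units; within the scatter) and so does not separate these two groups, which means that in this small set the clear gain comes from losing 2-fluorophenyl and not from adding a second 3,4,5-trimethoxyphenyl.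

As far as these compounds go, each swap rests on a single pair, so it remains open whether an amine in place of acetamido, or a plain phenyl in place of 3,4,5-trimethoxyphenyl, would keep the number this low. No independent measurement accompanies these results, so what lies behind any of these steps remains unknown.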